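The source may report more compounds than this note shows. Statements on the series, on what has been measured and on what is new or still open speak of the compounds shown alone.

Measured so far:
Compound 1, `COc1cc(/C=C/C(=O)c2cccc(-n3cc(-c4ccc(Cl)cc4)[nH]c3=O)c2)cc(OC)c1OC` — in a functional assay on HOP-92 cells (Homo sapiens) for inhibition (a higher number here means a weaker inhibitor of growth, a lower number a stronger inhibitor of growth), compound 1 is reported as "not active" (no number reported).
Compound 2, `COc1cc(/C=C/C(=O)c2cccc(-n3cc(-c4ccccc4)[nH]c3=O)c2)ccc1O` — in this assay compound 2 gives 2270 nM.
Compound 3, `O=C(/C=C/c1cccc(O)c1)c1cccc(-n2cc(-c3ccccc3)[nH]c2=O)c1` — in this assay compound 3 gives 5040 nM.

Compound 3 holds the highest of the two numbers; its nearest neighbour is compound 2, and the step of a 2.2-fold higher number from compound 2 to compound 3 (0.35 log units; beyond the scatter) lies beyond the scatter. Compound 4, `O=C(/C=C/c1cccc(O)c1)c1cccc(-n2cc(-c3ccc(Cl)cc3)[nH]c2=O)c1`, is still to be measured in this assay. It differs from compound 3 by chloro in place of hydrogen on an aromatic carbon. Among the measured compounds shown here, no measured step carries this change alone: compound 1 differs from compound 2 in two places, the chloro and the other aryl ring, and the two values show only that compound 1 is reported as "not active" (no number reported) where compound 2 gives a number. On that thin basis a step of a 1.6-fold higher number from compound 3 to compound 4 (0.20 log units; within the scatter) toward a higher number is expected, with considerable uncertainty. Compound 4 is estimated at 8000 nM, with a range of 2500 nM to 25000 nM.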

Compound 4, concentration for 50% growth inhibition: 1600 nM
Compound 4: the middle estimate sits 5.0-fold (0.70 log units) above what was measured, outside the stated range (below it).
By their numbers in this assay, from the lowest: compounds 4 and 2 (each within the scatter of the next); then compound 3.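

Chloro in place of hydrogen, para to a large group, now stands alone in one step in this assay: a 3.2-fold lower number from compound 3 to compound 4 (0.50 log units; beyond the scatter). The 4-chlorophenyl group therefore does not by itself remove the read-out: compound 4 gives 1600 nM, while compound 1, which carries the same group, reads "not active" (no number reported). No measurement at hand accounts for the step.

From the compounds shown here alone, whether chloro lowers the number to a similar extent with the 4-hydroxy-3-methoxyphenyl group of compound 2 stays open. Also open, going by these compounds, is how fluoro, methoxy or an amine would read in the same place.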